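Predicting an isoxazole amide where every measured value is a limit

The compounds below may be only part of what the source reports. "The series", "measured", "known", "first", "only" and "open" are said of these compounds alone.

Compound 1, `O=C(Nc1ccc(Cl)c(-c2nnc3c(Cl)cccn23)c1)c1ccc(C(F)(F)F)cc1Cl`, in a functional assay on T47D cells (Homo sapiens) for antiproliferative activity, read by MTT assay, with a stated time of 72 h; on this read-out higher numbers stand for weaker inhibition and lower numbers for stronger inhibition: > 100000 nM, a limit of the assay.
Compound 2, `O=C(Nc1ccc(Cl)c(-c2nnc3c(Cl)cccn23)c1)c1ccc(Cl)cc1`, in this assay: > 100000 nM, a limit of the assay.
Compound 3, `CS(=O)(=O)c1ccc(C(=O)Nc2ccc(Cl)c(-c3nnc4c(Cl)cccn34)c2)c(Cl)c1`, in this assay: > 100000 nM, a limit of the assay.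

Compound 2 therefore stands nowhere in particular on the numbers shown: it sits on the same limit as every other compound, and that limit is all the assay reports for it. Going by the values given here, the only step among the measured compounds, a step that the two limits leave unreadable from compound 1 to compound 3, is unreadable for the same reason, so its size cannot be stated.

The change to compound 4, `O=C(Nc1ccc(Cl)c(-c2nnc3c(Cl)cccn23)c1)c1ccon1`, is 1,2-oxazol-3-yl in place of 4-chlorophenyl on a carbonyl carbon. Among the compounds with values here, no measured step bears on this change, and the one evidence that exists is that (the limit of > 100000 nM in this assay, at which 3 of the 3 values shown sit), which tells nothing about direction or size. The expectation is therefore no readable step beyond the scatter, and the estimated step of a number no higher from compound 2 to compound 4 (the limit leaves the size open) is taken as flat. Compound 4 is expected to sit around 100000 nM, somewhere between 20000 nM and 300000 nM, most probably again as a limit rather than a number.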

Compound 4, half-maximal inhibitory concentration: > 100000 nM
Compound 4 gave a limit, no number (the forecaster's own chance of this, stated with the estimate: 75%); the middle value lies on the limit itself.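

In this assay compound 4 gives > 100000 nM, a limit of the assay and not a number. Going by these compounds alone, compound 2 also stands on a limit, so no step between compound 2 and compound 4 can be read: the limit of > 100000 nM in this assay, at which 4 of the 4 values shown sit. The compounds shown leave open whether 1,2-oxazol-3-yl and 4-chlorophenyl on the carbonyl carbon differ at all in this assay.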